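Positional shift of the carboxylic acid at the aryl ether end

This account rests on a few compounds, and the source may have more. Where it says the series, first, only, none or still open, it means among the compounds named here.

Measured so far:
compound 1, `Cc1c(OCCCCOc2ccc(C(=O)O)cc2F)ccc(C(=O)CC2CCCC2)c1O` — 639 nM
compound 2, `Cc1c(OCCCCOc2ccc(C(=O)O)cc2Cl)ccc(C(=O)CC2CCCC2)c1O` — 237 nM

In an assay on HEK293 cells for positive allosteric modulation of metabotropic glutamate receptor 2 (Rattus norvegicus), read by thallium flux, with a stated time of 2.5 min (on this read-out higher numbers stand for an effect only at larger amounts of compound and lower numbers for an effect already at smaller amounts), compound 2 gives 237 nM, the lowest of the two numbers recorded; its nearest neighbour is compound 1, and the step of a 2.7-fold lower number from compound 1 to compound 2 (0.43 log units; beyond the scatter) stands beyond the scatter. Compound 3, `Cc1c(OCCCCOc2cccc(C(=O)O)c2)ccc(C(=O)CC2CCCC2)c1O`, is not yet measured in this assay. It differs from compound 2 by 3-carboxyphenyl in place of 4-carboxy-2-chlorophenyl on an oxygen on a saturated carbon, so both the chlorine is removed and the carboxylic acid changes its position on the ring. Going by the values given here, only one measured step, a 2.7-fold lower number from compound 1 to compound 2 (0.43 log units; beyond the scatter), touches this change, and it concerns just the halogen; no measured pair speaks to the moved acid. Since the halogen swap alone moved the number beyond the scatter, removing the halogen altogether is expected to raise the number, and the shifted acid adds uncertainty. Compound 3 is therefore estimated at 1200 nM (range 350 nM to 4500 nM), a step of a 5.1-fold higher number from compound 2 to compound 3 (0.70 log units; beyond the scatter) expected in this assay.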

Compound 3, half-maximal effective concentration: 451 nM
Estimate against measurement, compound 3: 2.7-fold (0.43 log units) above, and the stated range covers the measured number.
By their numbers in this assay, from the lowest: compounds 2, 3 and 1 (each within the scatter of the next, the first and the last beyond it).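

In this assay, compound 3 cannot be told apart from either halogen-bearing compound (a 1.9-fold higher number from compound 2 to compound 3 (0.28 log units; within the scatter); a 1.4-fold lower number from compound 1 to compound 3 (0.15 log units; within the scatter)). This shows that, on the oxygen on a saturated carbon, a ring with no halogen and a differently placed carboxylic acid can give a number within the scatter of both compound 1 and compound 2, even though those two lie apart from each other. No evidence is available to explain this result.

Since compound 3 carries both changes at once, the compounds shown do not separate the effect of losing the chlorine from that of moving the carboxylic acid. They also leave open how 4-carboxyphenyl without a halogen, or a tetrazole in place of the carboxylic acid, would read out at this place.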